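A few compounds are considered here, and "the series" means these few. Any claim that something is new, unique, unknown or untested is made for them only; others in the source may bear on it.

Measured in a functional assay on MCF7 cells (Homo sapiens) for cytotoxicity, read by MTT assay, with a stated time of 96 h; a higher number here means a weaker inhibitor, a lower number a stronger inhibitor:
compound 1 `COc1cc(C(=O)c2cn(-c3ccccc3C)cc2-c2ccccc2)cc(OC)c1OC`: 2200 nM
compound 2 `COc1cc(C(=O)c2cn(-c3ccccc3)cc2-c2ccccc2C)cc(OC)c1OC`: 190 nM
compound 3 `COc1cc(C(=O)c2cn(-c3ccccc3)cc2-c2ccccc2Cl)cc(OC)c1OC`: 76 nM

Of these three, compound 3 has the lowest number at 76 nM, which makes it the strongest inhibitor so far. The next candidate is compound 4 `COc1cc(C(=O)c2cn(-c3ccccc3)cc2-c2ccc(Cl)cc2)cc(OC)c1OC`, which has not yet been measured. It has the same atoms as compound 3, joined differently, with 4-chlorophenyl in place of 2-chlorophenyl on an aromatic carbon.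

Among the compounds with values here, only one measured step is close to this change: a 2.5-fold lower number from compound 2 to compound 3 (0.40 log units; beyond the scatter). That modest step swaps methyl for chloro and does not move the chlorine, so it offers only indirect guidance. Within the data shown here, no measured pair shows the effect of moving a chlorine. Because compound 3 stands lowest at 76 nM, a modest rise seems more likely than a further fall, though with little certainty.

The estimate therefore means a 2.6-fold higher number from compound 3 to compound 4 (0.42 log units; beyond the scatter), an expected weakening in this assay. For compound 4, the estimated value is 200 nM, with an expected range of 40 nM to 900 nM.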

Compound 4, half-maximal inhibitory concentration: 290 nM
For compound 4 the middle estimate is 1.5-fold (0.16 log units) below the measured one; the measured number falls inside the stated range.
By their numbers in this assay, from the lowest: compound 3; then compounds 2 and 4 (each within the scatter of the next); then compound 1.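

In this assay, the chlorine stays on the same phenyl group and only its place on that ring changes, giving a 3.8-fold higher number from compound 3 to compound 4 (0.58 log units; beyond the scatter); the position of the chlorine therefore matters here, not just its presence. By contrast, exchanging 2-methylphenyl for 4-chlorophenyl gives a 1.5-fold higher number from compound 2 to compound 4 (0.18 log units; within the scatter), so that pair cannot be told apart in this test. No measurement here explains why 2-chlorophenyl gives a lower number than 4-chlorophenyl at this position.

Two chlorophenyl isomers cannot show whether this dependence on position extends to other groups on this ring. On these data alone, it remains open how a methoxy group, an amine or a carboxylic acid in place of the chlorine would affect the number.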